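This account rests on a few compounds, and the source may have more. Where it says the series, first, only, none or still open, it means among the compounds named here.

Measured compounds:
Compound 1 `CC(C)(C)c1ccc(NC(=O)c2ccc(-c3ccccn3)cc2)cc1` — 31 nM
Compound 2 `Cc1cccnc1-c1ccc(C(=O)Nc2ccc(C(C)(C)C)cc2)cc1` — 31 nM

In a functional assay on Dorsal root ganglion for antagonist activity at transient receptor potential cation channel subfamily V member 1 (Rattus norvegicus) (a higher number here means a weaker inhibitor, a lower number a stronger inhibitor), compound 1 gives 31 nM, and compound 2 gives 31 nM, so compound 1 stands level with compound 2. For the measured compounds named here, the only measured step, no change at the digits printed from compound 1 to compound 2 (within the scatter), is a methyl in place of hydrogen on an aromatic carbon and left the inhibitory concentration unchanged within the scatter.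

Compound 3 `CN(C(=O)c1ccc(-c2ccccn2)cc1)c1ccc(C(C)(C)C)cc1` is not yet measured in this assay. It differs from compound 1 by methyl in place of hydrogen on an amide-type nitrogen. Going by the values given here, no measured step touches the amide-type nitrogen; the one step that adds a methyl sits on an aromatic carbon and says nothing direct about this position. The expectation for compound 3 therefore rests on little, and the account holds open that the step of a 9.7-fold higher number from compound 1 to compound 3 (0.99 log units; beyond the scatter) may be sizeable and toward weaker inhibition. Compound 3 is expected to give about 300 nM, within a range from 40 nM to 3000 nM.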

Compound 3, half-maximal inhibitory concentration: 10000 nM
The estimate for compound 3 lay 33-fold (1.52 log units) below the measured number; the whole stated range lies below it.
By their numbers in this assay, from the lowest: compounds 1 and 2 (each within the scatter of the next); then compound 3.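

The amide-type nitrogen proves far less forgiving of a methyl than the aromatic carbon did: in this assay, methyl in place of the amide hydrogen gives a 320-fold higher number from compound 1 to compound 3 (2.51 log units; beyond the scatter), whereas methyl in place of hydrogen on the aromatic carbon gave no change at the digits printed from compound 1 to compound 2 (within the scatter). The same single added carbon thus has very different outcomes at these two places, so among these compounds the size of a methyl step depends on where it stands. Nothing available here bears on why this substitution costs so much inhibition.

The compounds shown leave open whether any group on this nitrogen gives a step of this size, or whether an ethyl or a longer chain there would behave differently. They also do not tell whether the same change would give a comparable step on the core of compound 2.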